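This account rests on a few compounds, and the source may have more. Where it says the series, first, only, none or still open, it means among the compounds named here.

Measured so far in a functional assay on HOP-62 cells (Homo sapiens) for inhibition, read by sulforhodamine B assay; on this read-out higher numbers stand for weaker inhibition of growth and lower numbers for stronger inhibition of growth:

compound 1, `FC(F)(F)Oc1ccc(-c2ccc(-c3ccc(-c4nc5ccccc5[nH]4)cc3)cc2)cc1`, 100000 nM
compound 2, `Oc1ccc(-c2ccc(-c3ccc(-c4nc5ccccc5[nH]4)cc3)cc2)cc1`, 47200 nM
compound 3, `Oc1cccc2[nH]c(-c3ccc(-c4ccc(-c5ccc(OC(F)(F)F)cc5)cc4)cc3)nc12`, 2270 nM

Compound 3 stands lowest of the three, with a 44-fold lower number from compound 1 to compound 3 (1.64 log units; beyond the scatter).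

Compound 4, `Oc1ccc(-c2ccc(-c3ccc(-c4nc5c(O)cccc5[nH]4)cc3)cc2)cc1`, is not yet measured in this assay. It differs from compound 3 by hydrogen in place of trifluoromethyl on an oxygen on an aromatic ring. The same change has been measured once, from compound 1 to compound 2: hydrogen in place of trifluoromethyl on an oxygen on an aromatic ring, giving a 2.1-fold lower number from compound 1 to compound 2 (0.33 log units; beyond the scatter). The two cores differ by hydroxy in place of hydrogen on an aromatic carbon.

With a single earlier instance of the change and a core difference of that size, the step from compound 3 to compound 4 is expected to be of about the same modest size, a 2.1-fold lower number from compound 3 to compound 4 (0.31 log units; beyond the scatter), resting on compound 1 to compound 2 in this assay a 2.1-fold lower number from compound 1 to compound 2 (0.33 log units; beyond the scatter). Compound 4 is accordingly estimated at 1100 nM, with a range from 400 nM to 3200 nM.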

Compound 4, concentration for 50% growth inhibition: 2410 nM
Beside the measured number, compound 4's estimate is 2.2-fold (0.34 log units) below it, and the stated range covers the measured number.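

In this assay, going from trifluoromethoxy to hydroxy gives a 1.1-fold higher number from compound 3 to compound 4 (0.03 log units; within the scatter), and this step does not differ from the earlier one on the core of compound 1: the same change on two cores in this assay, a 2.1-fold lower number (0.33 log units; beyond the scatter) from compound 1 to compound 2 and a 1.1-fold higher number (0.03 log units; within the scatter) from compound 3 to compound 4, 2.2-fold (0.35 log units) apart, within the scatter of two such steps

The hydroxy on the aromatic carbon of the core also carries over, giving a 20-fold lower number from compound 2 to compound 4 (1.29 log units; beyond the scatter), again in line with its earlier step: the same change on two cores in this assay, a 44-fold lower number (1.64 log units; beyond the scatter) from compound 1 to compound 3 and a 20-fold lower number (1.29 log units; beyond the scatter) from compound 2 to compound 4, 2.2-fold (0.35 log units) apart, within the scatter of two such steps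

Going by these compounds alone, these two pairs show both changes carrying between two cores, but with only one pair of steps for each change, they do not establish that this holds across the series.

As far as these compounds go, it remains open whether an amine or a carboxylic acid in place of the hydroxy on the aromatic carbon would give a step of similar size. The same question stands for a longer chain on the oxygen in place of trifluoromethyl.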